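Single stereocentre inversion: compound 2 to compound 3

The compounds below may be only part of what the source reports. "The series", "measured", "known", "first", "only" and "open" are said of these compounds alone.

Compound 1 `Nc1ncnc2c1ncn2[C@@H]1O[C@H](CO)[C@@H](O[C@H]2O[C@H](CO)[C@@H](OP(=O)(O)O)[C@H](OP(=O)(O)O)[C@H]2O)[C@H]1OP(=O)(O)O` and compound 2 `O=P(O)(O)O[C@H]1CO[C@@H]2[C@H](O)[C@@H](OP(=O)(O)O)[C@H](OP(=O)(O)O)[C@@H](O)[C@@H]2OC1` are the two compounds with numbers in hand. In a functional assay (Hepatocyte) with Rattus norvegicus as the target (a higher number here means that more compound is needed for the effect, a lower number that less compound is needed), compound 1 gives 9.2 nM, whereas compound 2 gives 1230 nM, the higher of the two numbers and far beyond the scatter relative to compound 1. Compound 3 `O=P(O)(O)O[C@@H]1CO[C@@H]2[C@H](O)[C@@H](OP(=O)(O)O)[C@H](OP(=O)(O)O)[C@@H](O)[C@@H]2OC1` is the next compound to be tested. Relative to compound 2, the two compounds have the same atoms and bonds and differ only in configuration as drawn: 1 of 7 stereo elements differ; a stereocentre at a saturated ring carbon is drawn S in compound 2 and R in compound 3 No measured pair in this set differs by such a change, so nothing anchors the size of this step. Inverting one ring carbon of the shared core can move the number either way; the working expectation is a modest rise in this assay, near the edge of the scatter, with wide uncertainty. For compound 3 the estimate in this assay is 2000 nM, ranging from 400 nM to 12000 nM. This expected change corresponds to a step of a 1.6-fold higher number from compound 2 to compound 3 (0.21 log units; within the scatter).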

Compound 3, half-maximal effective concentration: 1650 nM
Compound 3: the middle estimate sits 1.2-fold (0.08 log units) above what was measured; low and high end bracket the measured number.
By their numbers in this assay, from the lowest: compound 1; then compounds 2 and 3 (each within the scatter of the next).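

In this assay, among the compounds shown here, inverting this saturated ring carbon from S to R gives a 1.3-fold higher number from compound 2 to compound 3 (0.13 log units; within the scatter), the first reading of a purely stereochemical change. At this position, then, the configuration as drawn does not separate the two compounds beyond the scatter. The comparison isolates that single stereocentre, with no atoms or bonds entering or leaving: the fact that compounds 2 and 3 differ only in the configuration as drawn.

This single pair says nothing about the other stereo elements of the shared core, which may not be as forgiving as this one. Also open, as far as these compounds go, is whether the number would hold if a carboxylic acid stood in place of a phosphate group on this scaffold, in either configuration at this carbon.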